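A few compounds are considered here, and "the series" means these few. Any claim that something is new, unique, unknown or untested is made for them only; others in the source may bear on it.

Compound 1 `CCNC(=O)c1cc(-c2ccc(F)cc2F)ccc1OC(C)=O` gives 23.9% in a functional assay on the whole organism (strain Kunming) for inhibition, with Mus musculus as the target, in the writhing test, at a dose of 40 mg/kg by the oral route (on this read-out higher numbers stand for more inhibition at the one dose given (going by the name of the read-out) and lower numbers for less inhibition), the second highest of three numbers: compound 2 `CC(=O)Oc1ccc(-c2ccc(F)cc2F)cc1C(=O)Nc1cccc(C)c1` gives 19% and compound 3 `CC(=O)Oc1ccc(-c2ccc(F)cc2F)cc1C(=O)Nc1ccc(C)cc1` gives 31%. Compound 4 `CC(=O)Oc1ccc(-c2ccc(F)cc2F)cc1C(=O)NN1CCOCC1` differs from compound 1 by morpholin-4-yl in place of ethyl on an amide-type nitrogen. Going by the values given here, the steps that bear on this change also replace the ethyl on the amide-type nitrogen: a number 4.9 percentage points lower from compound 1 to compound 2 (within the scatter) and a number 7.1 percentage points higher from compound 1 to compound 3 (within the scatter), both within the scatter, while a number 12 percentage points higher from compound 2 to compound 3 (beyond the scatter) is modest. Since neither replacement of ethyl moved this assay beyond the scatter, compound 4 is expected to stay near compound 1, with an estimated step of a number 1.1 percentage points higher from compound 1 to compound 4 (within the scatter). Compound 4 is therefore estimated at 25%, in a range from 12% to 38%.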

Compound 4, a percentage reported as inhibition, in the whole organism at one dose (the size of the read-out at that dose, not a potency): 28.5%
Compound 4: middle estimate off by 3.5 percentage points, on the low side; the measured number falls inside the stated range.
By their numbers in this assay, from the lowest: compounds 2, 1, 4 and 3 (each within the scatter of the next, the first and the last beyond it).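

Placed on the amide-type nitrogen, morpholin-4-yl adds a non-aromatic ring to the aryl and alkyl groups seen so far, and in this assay the steps are a number 4.6 percentage points higher from compound 1 to compound 4 (within the scatter) and a number 2.5 percentage points lower from compound 3 to compound 4 (within the scatter) and a number 9.5 percentage points higher from compound 2 to compound 4 (within the scatter) and so all lie within the scatter. Compound 4 thus cannot be told apart from any of the other three compounds, even though compound 2 and compound 3 remain separated beyond the scatter. No supporting measurement accounts for this result. As far as these compounds go, it remains open whether a longer chain such as n-butyl, or a carboxylic acid carried on this nitrogen, would shift the number beyond the scatter.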